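The compounds below may be only part of what the source reports. "The series", "measured", "known", "first", "only" and "open" are said of these compounds alone.

Three compounds share a core in which a carbonyl joins a chain ending in a phenyl ring to a small aromatic ring. Compound 1 `O=C(CCCCCCc1ccccc1)c1nc(Cl)co1` carries a chlorine on that ring and gives 2400 nM in an assay on HEK-293T cells for inhibition of diacylglycerol lipase-alpha (Homo sapiens), read by colorimetric assay; on this read-out lower numbers stand for stronger inhibition and higher numbers for weaker inhibition. Compound 2 `CN(C)C(=O)c1cnc(C(=O)CCCCCCc2ccccc2)o1` carries a dimethylcarbamoyl group; in this assay compound 2 reaches only > 10000 nM, a limit of the measurement rather than a number. Compound 3 `CSc1cnc(C(=O)CCCCCCc2ccccc2)o1` carries a methylsulfanyl group; in this assay compound 3 likewise stops at > 10000 nM, again a limit and not a number. Compound 3 therefore stands at the weak end of what has been seen: an at least 4.1-fold higher number from compound 1 to compound 3 (0.61 log units; beyond the scatter), while a step that the two limits leave unreadable from compound 2 to compound 3. Both weaker compounds rest on (the limit of > 10000 nM in this assay, at which 2 of the 3 values shown sit).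

Compound 4 `COc1ccc(-c2cnc(C(=O)CCCCCCc3ccccc3)o2)nc1` differs from compound 3 by 5-methoxypyridin-2-yl in place of methylsulfanyl on an aromatic carbon. Among the measured compounds shown here, no measured step exchanges a small group for a ring at this position, so the direction of the expected step of an at least 5.0-fold lower number from compound 3 to compound 4 (0.69 log units; beyond the scatter) is uncertain. Compound 4 is estimated at 2000 nM, within 300 nM to 15000 nM, with a real chance that only a limit is returned.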

Compound 4, half-maximal inhibitory concentration: > 10000 nM
Compound 4: a limit, no number; the forecaster's own chance of this, stated with the estimate: 35%; middle value at least 5.0-fold (0.69 log units) away from the limit.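

Compound 4 returns only a limit, not a number, so its steps from compound 2 and compound 3 cannot be read: (the limit of > 10000 nM in this assay, at which 3 of the 4 values shown sit). The compounds shown leave open how compound 2, compound 3 and compound 4 rank against one another.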